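Swapping a thiazolylmethyl ester for an ethyl ester

A few compounds are considered here, and "the series" means these few. Any claim that something is new, unique, unknown or untested is made for them only; others in the source may bear on it.

Compound 2 `CC(C)(C)C(=O)OCO[P@@]1(=O)OCC(C)(C)[C@H](C(=O)NCCC(=O)OCc2cncs2)O1` and compound 1 `CC(C)(C)C(=O)OCO[P@@]1(=O)OCC(C)(C)[C@H](C(=O)NCCC(=O)OCCS(C)(=O)=O)O1` share one core and differ only at the ester end. In an ADME assay on blood (Homo sapiens) for pharmacokinetics (on this read-out higher numbers stand for a longer-lived compound and lower numbers for a shorter-lived compound), compound 1 gives only a limit of the assay, < 0.16 h. In this assay compound 2 likewise gives only a limit, < 0.16 h. The step between them is a step that the two limits leave unreadable from compound 1 to compound 2, since both rest at the limit of < 0.16 h in this assay, at which 2 of the 2 values shown sit. Compound 3 `CCOC(=O)CCNC(=O)[C@@H]1O[P@@](=O)(OCOC(=O)C(C)(C)C)OCC1(C)C` differs from compound 2 by methyl in place of 1,3-thiazol-5-yl on a saturated chain carbon bound to an oxygen next to a carbonyl group. Within the data shown here, no measured step speaks to this change, so the expected step that the limit leaves unreadable from compound 2 to compound 3 is small. Compound 3 is therefore expected near 0.12 h, estimated between 0.04 h and 0.4 h.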

Compound 3, half-life: 0.28 h
Estimate against measurement, compound 3: 2.3-fold (0.37 log units) below, and the stated range covers the measured number.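

In this assay compound 3, the ethyl ester, gives a readable number rather than a limit, unlike the two earlier compounds: the limit of < 0.16 h in this assay, at which 2 of the 3 values shown sit. Methyl in place of 1,3-thiazol-5-yl gives an at least 1.7-fold higher number from compound 2 to compound 3 (0.24 log units; that floor lies within the scatter), and hydrogen in place of methylsulfonyl gives an at least 1.7-fold higher number from compound 1 to compound 3 (0.24 log units; that floor lies within the scatter). Both steps are only floors, so the true gaps could be larger, but as printed neither floor clears the scatter.

Going by these compounds, how far compound 1 and compound 2 truly lie from compound 3 stays open. So does whether a longer chain, such as propyl, or a phenyl ring at this place would change the half-life.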